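The source may hold more compounds than are shown below. What is called first, only, known or untested is meant among the compounds shown, and "the series" means these compounds.

Measured so far in a functional assay on HEK293 cells with Glucose-dependent insulinotropic receptor (Homo sapiens) as the target, read by cAMP accumulation, with a stated time of 60 min; on this read-out higher numbers stand for larger maximal responses and lower numbers for smaller maximal responses:
compound 1, `CCCS(=O)(=O)N1CC=C(c2ccc3c(c2)CC(C2CCN(Cc4ccccc4)CC2)O3)CC1`: 88%
compound 2, `CCCS(=O)(=O)N1CC=C(c2ccc3c(c2)CC(C2CCN(c4ncc(Cl)cn4)CC2)O3)CC1`: 88%

Among the compounds with values here, the only step measured, no change at the digits printed from compound 1 to compound 2 (within the scatter), left the largest response unchanged when the group on the amine nitrogen in a ring was exchanged. Compound 2 therefore stands level with compound 1 in this assay, with no difference beyond the scatter.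

Compound 3, `CCCS(=O)(=O)N1CC=C(c2ccc3c(c2)CC(C2CCN(c4ccc(C(F)(F)F)cn4)CC2)O3)CC1`, differs from compound 2 as follows: 5-(trifluoromethyl)pyridin-2-yl in place of 5-chloropyrimidin-2-yl on an amine nitrogen in a ring. Within the data shown here, this is again an exchange of the group on the same ring nitrogen, and the one prior step of that kind bears on it. On that basis no step beyond the scatter is expected for compound 3, a number 2 percentage points lower from compound 2 to compound 3 (within the scatter). Compound 3 is estimated at 86%, range 70% to 100%.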

Compound 3, largest response reached (Emax), in percent of the reference or control that the assay uses: 99%
Estimate against measurement, compound 3: 13 percentage points below, and the stated range covers the measured number.
By their numbers in this assay, from the lowest: compounds 1 and 2 (each within the scatter of the next); then compound 3.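

In this assay the group on the amine nitrogen in a ring can change the largest response: there is a number 11 percentage points higher from compound 2 to compound 3 (beyond the scatter) and also a number 11 percentage points higher from compound 1 to compound 3 (beyond the scatter), whereas the earlier exchange at this nitrogen gave no step beyond the scatter. The 5-(trifluoromethyl)pyridin-2-yl group thus stands apart from both 5-chloropyrimidin-2-yl and benzyl here, though only modestly. Nothing on hand accounts for this step.

The compounds shown do not separate the trifluoromethyl group from the ring that carries it. A chloropyridine or a trifluoromethylpyrimidine on the same nitrogen would divide the two.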